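The compounds below may be only part of what the source reports. "The series", "measured", "known", "first", "only" and "open" are said of these compounds alone.

Compound 3 `OCCNc1[nH]ccc2ncnc1-2` carries a (2-hydroxyethyl)amino group on the shared core. In a functional assay on the whole organism (Pleural cavity) with Rattus norvegicus as the target (a lower number here means that less compound is needed, a higher number that more compound is needed for the effect), compound 3 stops at the limit of the test, > 9 mg/kg, which is not a number. Compound 2 `Sc1[nH]ccc2ncnc1-2` gives 8 mg/kg in this assay, so the step of an at least 1.1-fold higher number from compound 2 to compound 3 (0.05 log units; that floor lies within the scatter) can be read only from that side. Compound 1 `Clc1[nH]ccc2ncnc1-2` also ends at a limit in this assay, > 9 mg/kg. The step that the two limits leave unreadable from compound 1 to compound 3 adds nothing readable, as the limit of > 9 mg/kg in this assay, at which 2 of the 3 values shown sit, shows. Compound 4 `CN(C)c1[nH]ccc2ncnc1-2` differs from compound 3 by dimethylamino in place of (2-hydroxyethyl)amino on an aromatic carbon. Since compound 3 is known only as a limit, the step that the limit leaves unreadable from compound 3 to compound 4 is expected to be small and uncertain. Compound 4 is therefore estimated at 12 mg/kg, with a range from 5 mg/kg to 30 mg/kg.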

Compound 4, dose for half-maximal effect: 9 mg/kg
Compound 4: middle estimate off by 1.3-fold (0.12 log units), on the high side, within the range that was stated.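

Compound 4 shows that a group joined through nitrogen at this aromatic carbon can give a measured value rather than a limit. In this assay, dimethylamino in place of (2-hydroxyethyl)amino gives a number no higher from compound 3 to compound 4 (the limit leaves the size open), and dimethylamino in place of chloro gives a number no higher from compound 1 to compound 4 (the limit leaves the size open). In this assay, dimethylamino in place of sulfanyl gives a 1.1-fold higher number from compound 2 to compound 4 (0.05 log units; within the scatter), so these two groups cannot be told apart here. The sizes of the steps to compound 4 from compound 1 and compound 3 cannot be read, as each starts from a limit: the limit of > 9 mg/kg in this assay, at which 2 of the 4 values shown sit.

On these data alone, it remains open whether any group at this position moves the dose beyond the scatter. A ring amine such as morpholine, a longer chain on the nitrogen or a carboxylic acid could test this.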